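The source may report more compounds than this note shows. Statements on the series, on what has been measured and on what is new or still open speak of the compounds shown alone.

Measured in a functional assay on LS174T cells (Homo sapiens) for cytotoxicity, read by MTT assay, with a stated time of 72 h (a higher number here means a weaker inhibitor, a lower number a stronger inhibitor), where each value is a limit and not a number:

- Compound 1 `COCOc1cc(/C=C/C(=O)OCC(=O)Nc2ccc(OC)cc2)ccc1OCc1ccccc1`: > 200000 nM
- Compound 2 `O=C(COC(=O)/C=C/c1ccc(O)c(O)c1)NN1CCOCC1`: > 200000 nM
- Compound 3 `COc1ccc(NC(=O)COC(=O)/C=C/c2ccc(OCc3ccccc3)c(O)c2)cc1`: > 200000 nM

Compound 3 therefore has no exact place on the scale, and its result is a limit. It shares that position with the other two compounds, as shown by the limit of > 200000 nM in this assay, at which 3 of the 3 values shown sit.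

Compound 4 `COc1ccc(NC(=O)COC(=O)/C=C/c2ccc(O)c(O)c2)cc1` differs from compound 3 by one change, benzyloxy to hydroxy: hydrogen in place of benzyl on an oxygen on an aromatic ring. The closest measured step is a step that the two limits leave unreadable from compound 1 to compound 3, where hydrogen replaces methoxymethyl on an oxygen on an aromatic ring. It gives no size to carry over. Compound 2 also has hydrogen on such an oxygen, and its result of > 200000 nM is again a limit.

With no readable step to build on, only a modest move towards a lower number in this assay is expected, and perhaps none, as the estimated at least 1.3-fold lower number from compound 3 to compound 4 (0.12 log units; that floor lies within the scatter). Compound 4 is estimated at 150000 nM, with an expected range of 50000 nM to 300000 nM.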

Compound 4, half-maximal inhibitory concentration: 124000 nM
Estimate against measurement, compound 4: 1.2-fold (0.08 log units) above; low and high end bracket the measured number.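

In this assay, compound 4 is the first compound shown to give an exact number rather than a limit. Placing hydrogen on the oxygen gives an at least 1.6-fold lower number from compound 3 to compound 4 (0.20 log units; that floor lies within the scatter), and placing 4-methoxyphenyl on the amide-type nitrogen gives an at least 1.6-fold lower number from compound 2 to compound 4 (0.20 log units; that floor lies within the scatter), so the number appears only where the two features occur together, though each step is only a small floor. Compound 1, compound 2 and compound 3 each remain at a limit and not a number: the limit of > 200000 nM in this assay, at which 3 of the 4 values shown sit.

The step between compound 1 and compound 3 cannot be read, so the effect of the groups on that oxygen remains unsized. From the compounds shown here alone, it also remains open whether a methyl on that oxygen, or an amine in place of the hydroxy, would move the number further.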